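This account rests on a few compounds, and the source may have more. Where it says the series, first, only, none or still open, it means among the compounds named here.

Measured compounds:
Compound 1 `COc1nn(Cc2cccc3ccccc23)c(=O)o1`: 35%
Compound 2 `COc1nn(Cc2ccc([N+](=O)[O-])cc2)c(=O)o1`: 18%

Going by the values given here, in an assay on COS-7 cells for inhibition of Fatty-acid amide hydrolase 1 (Homo sapiens), read by scintillation counting, with a stated time of 10 min, tested at 10 uM (on this read-out higher numbers stand for more inhibition at the one concentration tested (going by the name of the read-out) and lower numbers for less inhibition), compound 2 gives 18%, the lower of the two numbers; the only other value, that of compound 1 at 35%, lies beyond the scatter above it. Compound 3 `COc1nn(Cc2ccc(NC(C)=O)cc2)c(=O)o1` has not been measured. It differs from compound 2 in one place: acetamido in place of nitro on an aromatic carbon. Among the compounds with values here, no step between measured compounds resembles this change, so a firm direction cannot be drawn from the data, and the expected step of a number 4 percentage points higher from compound 2 to compound 3 (within the scatter) is small, within the scatter. Compound 3 is estimated at 22%, with a range from 5% to 40%.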

Compound 3, a percentage reported as inhibition, at one concentration (the size of the read-out at that concentration, not a potency): 37%
The estimate for compound 3 lay 15 percentage points below the measured number; low and high end bracket the measured number.
By their numbers in this assay, from the lowest: compound 2; then compounds 1 and 3 (each within the scatter of the next).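

In this assay, acetamido in place of nitro on this aromatic carbon gives a number 19 percentage points higher from compound 2 to compound 3 (beyond the scatter), the first sign that inhibition responds to what this position carries. With the rest of the structure unchanged, the difference can be assigned to this one exchange. No measurement at hand explains the step. The compounds shown leave open how an amine, a carboxylic acid or a longer acyl chain on the same aromatic carbon would read. They also leave open whether the step reflects the loss of nitro or the arrival of acetamido.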